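This account rests on a few compounds, and the source may have more. Where it says the series, first, only, none or still open, it means among the compounds named here.

Of the compounds shown here, two sharing one core have been tested in a functional assay on A-375 cells (Homo sapiens) for antiproliferative activity, read by CCK-8 assay, with a stated time of 72 h, tested at 2 uM; on this read-out lower numbers stand for a weaker effect and higher numbers for a stronger effect at the one concentration tested. Compound 1, with the structure `Nc1ccccc1NC(=O)c1ccc(CSC(=S)N2CCN(c3cccnc3)CC2)cc1`, gives 40.5% in this assay, the higher of the two numbers recorded. Compound 2, with the structure `Nc1ccccc1NC(=O)c1ccc(CSC(=S)N(Cc2ccccc2)Cc2ccccc2)cc1`, gives 10.9% in this assay, a number well below that of compound 1 and beyond the scatter of the method; the two structures differ in more than one place, so their pair alone says nothing about any single change.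

Compound 3, with the structure `Nc1ccccc1NC(=O)c1ccc(CSC(=S)N2CCN(C3CCCCC3)CC2)cc1`, has not yet been measured in this assay. It differs from compound 1 in one place: cyclohexyl in place of pyridin-3-yl on an amine nitrogen in a ring.

Going by the values given here, no measured pair shows this change, so the size of the step can only be guessed. A cyclohexyl in place of a pyridin-3-yl on the amine nitrogen in the ring is expected to leave compound 3 somewhat weaker than compound 1, with an estimated step of a number 10.5 percentage points lower from compound 1 to compound 3 (beyond the scatter) in this assay, possibly within the scatter. Compound 3 is therefore estimated to give 30% in this assay, with a likely range from 10% to 52%.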

Compound 3, a percentage reported as inhibition, at one concentration (the size of the read-out at that concentration, not a potency): 31.7%
Compound 3: the middle estimate sits 1.7 percentage points below what was measured, and the stated range covers the measured number.
By their numbers in this assay, from the lowest: compound 2; then compounds 3 and 1 (each within the scatter of the next).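

In this assay, going by these compounds alone, the pair gives the first comparison that changes only one place, the group on the amine nitrogen in the six-membered ring, and exchanging pyridin-3-yl for cyclohexyl there gives a number 8.8 percentage points lower from compound 1 to compound 3 (within the scatter). At this one position and with this one pair, a ring of carbon only with no hydrogen-bond acceptor therefore cannot be told apart from an aromatic ring that holds a nitrogen and one acceptor, so the compounds give no sign that the aromatic ring or its nitrogen is needed for the effect at the tested concentration. Nothing available explains this outcome or says what either group does in the cells.

The compounds shown leave open whether the position accepts groups of a different size or kind, such as a methyl, a longer alkyl chain, a phenyl ring or a carboxylic acid, on the same ring nitrogen. Compound 2 differs from compound 1 and compound 3 in more than one place, so its steps to them cannot be read, and what the piperazine-type ring itself contributes also stays unresolved.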